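This account rests on a few compounds, and the source may have more. Where it says the series, first, only, none or still open, it means among the compounds named here.

Working notes on the series. In an ADME assay on L6 cells (Rattus norvegicus) for cytotoxicity, read by fluorescence and resazurin assay, with a stated time of 72 h (a higher number here means that more compound is needed for the effect, a lower number that less compound is needed), compound 1 (`O=c1nc(-c2ccccc2)c2cc(-c3cccnc3)ccc2[nH]1`) gives > 50000 nM as a limit, not a number. Compound 2 (`Cc1ccc(-c2ccc3[nH]c(=O)nc(-c4ccccc4)c3c2)cn1`) gives > 50000 nM as a limit too. Compound 3 (`O=c1nc(-c2ccccc2)c2cc(-c3cnc4ccccc4c3)ccc2[nH]1`) gives > 16000 nM as a limit as well. Compound 1 therefore stands at the limit of > 50000 nM in this assay, at which 2 of the 3 values shown sit, and has no readable number.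

Compound 4 (`O=c1nc(-c2ccccc2)c2cc(-c3ccccc3)ccc2[nH]1`) is not yet measured in this assay and carries phenyl in place of pyridin-3-yl on an aromatic carbon of the core of compound 1 phenyl in place of pyridin-3-yl on an aromatic carbon with the rest unchanged.

Among the compounds with values here, the one measured step is a step that the two limits leave unreadable from compound 1 to compound 2 and it concerns a methyl in place of hydrogen on an aromatic carbon. Within the data shown here, it offers no size to carry over, and no measured step covers the change to phenyl. The expectation therefore rests on compound 1 at > 50000 nM as a limit, and no step beyond the scatter is expected in this assay. The estimated step is an at least 1.2-fold lower number from compound 1 to compound 4 (0.09 log units; that floor lies within the scatter) and any real move is expected towards lower numbers. For compound 4 the expected value is 40000 nM within an estimated range of 15000 nM to 60000 nM and a report as a limit is quite likely.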

Compound 4, half-maximal effective concentration: > 50000 nM
Compound 4 gave a limit, no number; the forecaster's own chance of this, stated with the estimate: 55%; at least 1.2-fold (0.09 log units) between middle value and limit.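

In this assay compound 4 gives > 50000 nM, a limit and not a number. The steps to compound 4 from compound 1 and from compound 2 have limits at both ends and cannot be read. The compounds shown leave open whether phenyl, pyridin-3-yl and 6-methylpyridin-3-yl differ at all in this assay.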